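Adding Trifluoromethyl to a Mitochondrial Activator Scaffold

The source may report more compounds than this note shows. Statements on the series, on what has been measured and on what is new or still open speak of the compounds shown alone.

Compound 1 `Fc1ccccc1Nc1nc2nonc2nc1Nc1ccccc1`: 2200 nM
Compound 2 `Cc1cccc(Nc2nc3nonc3nc2Nc2ccccc2F)c1`: 1500 nM
Compound 3 `Fc1ccccc1Nc1nc2nonc2nc1Nc1ccccc1OC(F)(F)F`: 1700 nM

In an assay on mitochondria from L6 cells (Rattus norvegicus) for activation, with a stated time of 90 min (on this read-out higher numbers stand for an effect only at larger amounts of compound and lower numbers for an effect already at smaller amounts), compound 1 stands at the upper end of the three numbers, yet neither measured step away from it leaves the scatter: a 1.5-fold lower number from compound 1 to compound 2 (0.17 log units; within the scatter) and a 1.3-fold lower number from compound 1 to compound 3 (0.11 log units; within the scatter). Compound 4 `Fc1ccccc1Nc1nc2nonc2nc1Nc1ccc(C(F)(F)F)cc1` is compound 1 with trifluoromethyl in place of hydrogen on an aromatic carbon. Both measured steps alter the same outer ring of the shared core, and both stayed within the scatter, so no shift beyond the scatter is expected in this assay; the step of a 1.2-fold lower number from compound 1 to compound 4 (0.09 log units; within the scatter) is estimated on that basis. The value of compound 4 is therefore expected near 1800 nM, within a range of 600 nM to 5500 nM.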

Compound 4, half-maximal effective concentration: 270 nM
Compound 4: middle estimate off by 6.7-fold (0.82 log units), on the high side, and the stated range ends above it.
By their numbers in this assay, from the lowest: compound 4; then compounds 2, 3 and 1 (each within the scatter of the next).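

In this assay, within the data shown here, trifluoromethyl on an aromatic carbon para to a large group gives an 8.1-fold lower number from compound 1 to compound 4 (0.91 log units; beyond the scatter) and so provides the first step here that lies beyond the scatter. This shows that a single change on this outer ring can move the number clearly, which the methyl of compound 2 and the trifluoromethoxy of compound 3 did not show. From the compounds shown here alone, whether the shift belongs to trifluoromethyl itself or to this place stays open, and an amine or a carboxylic acid on the same carbon would help separate the two. Nothing measured here gives a reason for the step.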